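Swapping cyano for (piperazin-1-yl)sulfonyl at the assay limit

A few compounds are considered here, and "the series" means these few. Any claim that something is new, unique, unknown or untested is made for them only; others in the source may bear on it.

In a functional assay on L1210 cells (Mus musculus) for inhibition (on this read-out higher numbers stand for weaker inhibition and lower numbers for stronger inhibition), compound 2 `C#CCN(Cc1ccc2nc(C)nc(O)c2c1)c1ccc(C#N)cc1` sits at the limit of > 5000 nM in this assay, at which 1 of the 3 values shown sits. Its reading of > 5000 nM is a limit and not a number.

Compound 4 `C#CCN(Cc1ccc2nc(C)nc(O)c2c1)c1ccc(S(=O)(=O)N2CCNCC2)cc1` differs from it by (piperazin-1-yl)sulfonyl in place of cyano on an aromatic carbon, which in words is (piperazin-1-yl)sulfonyl in place of cyano on an aromatic carbon.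

Going by the values given here, two measured steps bear on this change: a number no lower from compound 1 to compound 2 (the limit leaves the size open) and an at least 1.1-fold lower number from compound 2 to compound 3 (0.04 log units; that floor lies within the scatter). Neither brings in a group like the incoming one, so neither gives a size to carry over directly.

Compound 1 `C#CCN(Cc1ccc2nc(C)nc(O)c2c1)c1cccc(CC)c1` gives 5000 nM and compound 3 `C#CCN(Cc1ccc2nc(C)nc(O)c2c1)c1ccc(C#N)c(Cl)c1` gives 4500 nM.

The step expected in this assay is therefore a step that the limit leaves unreadable from compound 2 to compound 4, which is estimated to stay within the scatter.

For compound 4 the expected value is 6000 nM, with an estimated range of 2000 nM to 20000 nM.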

Compound 4, half-maximal inhibitory concentration: > 50000 nM
Compound 4: no number, only a limit; the forecaster's own chance of this, stated with the estimate: 45%; at least 8.3-fold (0.92 log units) between middle value and limit.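

Going by these compounds alone, compound 2 and compound 4 each give only a limit, not a number, so no step between them can be read. The compounds shown leave open how far (piperazin-1-yl)sulfonyl in place of cyano shifts inhibition.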